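Swapping the ether aryl group: naphthalen-2-yl against 2-methylphenyl

The source may report more compounds than this note shows. Statements on the series, on what has been measured and on what is new or still open speak of the compounds shown alone.

Measured so far in a functional assay on MCF7 cells (Homo sapiens) for inhibition, read by MTT assay, with a stated time of 24 h; a higher number here means a weaker inhibitor, a lower number a stronger inhibitor:
Compound 1 `O=C1CSC(c2c[nH]nc2-c2ccc(Cl)cc2)N1n1c(S)nnc1COc1cccc2ccccc12`: 100 ug/mL
Compound 2 `Cc1ccccc1OCc1nnc(S)n1N1C(=O)CSC1c1c[nH]nc1-c1ccc(Cl)cc1`: 22 ug/mL
Compound 3 `COc1ccc(-c2n[nH]cc2C2SCC(=O)N2n2c(S)nnc2COc2ccccc2C)cc1`: 29 ug/mL

Compound 2 sits at the strong end of these three numbers. The step of a 1.3-fold higher number from compound 2 to compound 3 (0.12 log units; within the scatter) is within the scatter, so those two cannot be ranked, whereas a 4.5-fold lower number from compound 1 to compound 2 (0.66 log units; beyond the scatter) is beyond it.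

Compound 4 `O=C1CSC(c2c[nH]nc2-c2ccc(Cl)cc2)N1n1c(S)nnc1COc1ccc2ccccc2c1` carries the change (naphthalen-2-yl in place of 2-methylphenyl on an oxygen on a saturated carbon). Among the compounds with values here, the only step that bears on it is a 4.5-fold lower number from compound 1 to compound 2 (0.66 log units; beyond the scatter), where the other naphthyl isomer gave a clearly higher number than 2-methylphenyl. A return to a naphthyl group is therefore expected to raise the number again, though the isomer differs, so the size is uncertain; the expected step is a 2.5-fold higher number from compound 2 to compound 4 (0.40 log units; beyond the scatter).

Compound 4 is estimated at 55 ug/mL in this assay, within 20 ug/mL to 120 ug/mL.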

Compound 4, half-maximal inhibitory concentration: 100 ug/mL
For compound 4 the middle estimate is 1.8-fold (0.26 log units) below the measured one, and the stated range covers the measured number.
By their numbers in this assay, from the lowest: compounds 2 and 3 (each within the scatter of the next); then compounds 1 and 4 (each within the scatter of the next).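

In this assay, naphthalen-2-yl on this oxygen, like naphthalen-1-yl before it, gives a weaker inhibitor than 2-methylphenyl (a 4.5-fold higher number from compound 2 to compound 4 (0.66 log units; beyond the scatter)). Moving the attachment point of the naphthyl group changes nothing that can be seen here (no change at the digits printed from compound 1 to compound 4 (within the scatter)), so the two isomers cannot be ranked. Nothing available explains why both naphthyl compounds differ from compound 2.

The compounds shown leave open whether an unsubstituted phenyl, or a chain ending in an amine, on this oxygen would match or improve on 2-methylphenyl.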